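The source may hold more compounds than are shown below. What is called first, only, known or untested is meant among the compounds shown, and "the series" means these compounds.

Compound 1 `Cc1ccc(CSc2nnc(-c3ccc4c(c3)OCCO4)n2-c2ccccc2)cc1` gives 44300 nM in a functional assay on BGC-823 cells (Homo sapiens) for antiproliferative activity, read by MTT assay, with a stated time of 24 h; on this read-out higher numbers stand for weaker inhibition and lower numbers for stronger inhibition.
Compound 2 `Fc1ccc(CSc2nnc(-c3ccc4c(c3)OCCO4)n2-c2ccccc2)c(F)c1` gives > 100000 nM, which is a limit of the assay and not a number.

Compound 2 therefore stands at the limit of > 100000 nM in this assay, at which 1 of the 2 values shown sits, and where it truly lies is known only as a range. Compound 3 `Brc1cccc(CSc2nnc(-c3ccc4c(c3)OCCO4)n2-c2ccccc2)c1` differs from compound 2 by 3-bromophenyl in place of 2,4-difluorophenyl on a saturated chain carbon bound to a sulfur. For the measured compounds named here, the single measured step at this position, an at least 2.2-fold higher number from compound 1 to compound 2 (0.35 log units; beyond the scatter), shows that exchanging this group can shift the number beyond the scatter. Since compound 2 is known only as a limit, the step of an at least 1.6-fold lower number from compound 2 to compound 3 (0.22 log units; that floor lies within the scatter) is expected to be modest at most. Compound 3 is estimated at 60000 nM, between 25000 nM and 150000 nM.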

Compound 3, half-maximal inhibitory concentration: 65600 nM
Estimate against measurement, compound 3: 1.1-fold (0.04 log units) below; the measured number falls inside the stated range.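

Exchanging 4-methylphenyl for 3-bromophenyl on the saturated chain carbon bound to a sulfur gives a 1.5-fold higher number from compound 1 to compound 3 (0.17 log units; within the scatter), so these two substituted rings cannot be told apart here. Exchanging 2,4-difluorophenyl for 3-bromophenyl gives an at least 1.5-fold lower number from compound 2 to compound 3 (0.18 log units; that floor lies within the scatter), so this step may be small or large. Compound 2 remains a limit, not a number: the limit of > 100000 nM in this assay, at which 1 of the 3 values shown sits.

As far as these compounds go, whether an amine or a carboxylic acid in place of these rings would change the number beyond the scatter stays open. So does the effect of a longer chain between the sulfur and the ring.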